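The compounds below may be only part of what the source reports. "The series", "measured", "known", "first", "only" and "open" are said of these compounds alone.

Compounds measured so far in an assay on cells (Endothelial cell) for binding affinity to Endothelin-1 receptor (Sus scrofa); on this read-out higher numbers stand for weaker inhibition and lower numbers for stronger inhibition:
- compound 1 `COc1cccc(Oc2c(NS(=O)(=O)c3ccc(C(C)(C)C)cc3)ncnc2OCCO)c1`: 160 nM
- compound 2 `COc1cccc(Oc2c(NS(=O)(=O)c3ccc(C(C)(C)C)cc3)ncnc2OCCOc2ncccn2)c1`: 1.9 nM
- compound 3 `COc1cccc(Oc2c(NS(=O)(=O)c3ccc(C(C)(C)C)cc3)ncnc2OCCOc2nccs2)c1`: 12 nM

Compound 1 stands at the highest number of the three, so it is the weakest of the set in this assay; its nearest neighbour is compound 3 and the furthest is compound 2. The two measured steps both start from compound 1 and both add an aromatic ring to the oxygen on the saturated carbon: the pyrimidin-2-yl brings an 84-fold lower number from compound 1 to compound 2 (1.93 log units; beyond the scatter), the 1,3-thiazol-2-yl brings a 13-fold lower number from compound 1 to compound 3 (1.12 log units; beyond the scatter), and between the two rings the gap is a 6.3-fold higher number from compound 2 to compound 3 (0.80 log units; beyond the scatter).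

Compound 4 `COc1cccc(Oc2c(NCCOc3ncccn3)ncnc2NS(=O)(=O)c2ccc(C(C)(C)C)cc2)c1` is still to be measured. Its change from compound 1 is (2-((pyrimidin-2-yl)oxy)ethyl)amino in place of 2-hydroxyethoxy on an aromatic carbon. Among the measured compounds shown here, the change shares the pyrimidin-2-yl unit on the oxygen with compound 2, but the group is now joined to the ring through an amino rather than through the oxygen of compound 1, and no measured pair tests that exchange of the link. The step from compound 1 to compound 2 bears most directly, so a move in the same direction is expected, though with a wider band. The expected step is a 16-fold lower number from compound 1 to compound 4 (1.20 log units; beyond the scatter), and compound 4 is estimated at 10 nM, within 2 nM to 60 nM.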

Compound 4, half-maximal inhibitory concentration: 6.2 nM
For compound 4 the middle estimate is 1.6-fold (0.21 log units) above the measured one; the range from low to high includes it.
By their numbers in this assay, from the lowest: compound 2; then compounds 4 and 3 (each within the scatter of the next); then compound 1.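

In this assay the oxygen at this aromatic carbon, next to the ring nitrogen, proves not to be required for a large gain, since the amino-linked chain still gives a 26-fold lower number from compound 1 to compound 4 (1.41 log units; beyond the scatter) and so keeps a step of the same large class as the one seen with the ether-linked pyrimidin-2-yl group. The exchange of the link itself, with the pyrimidin-2-yl unit and the rest of the chain held constant, now has a direct reading: it gives a 3.3-fold higher number from compound 2 to compound 4 (0.51 log units; beyond the scatter) and therefore has a modest but real cost, while the comparison with the thiazole ether shows a 1.9-fold lower number from compound 3 to compound 4 (0.29 log units; within the scatter) and places those two compounds within the scatter of each other. Nothing available accounts for the cost of exchanging the oxygen for the amino link.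

The compounds shown leave open whether a 1,3-thiazol-2-yl group on the same amino-linked chain would follow the order seen for the two ethers. They also leave open how a sulfur link at this carbon, a methylated amine or a longer chain carrying the pyrimidin-2-yl group would compare.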